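The source may hold more compounds than are shown below. What is called first, only, known or untested is meant among the compounds shown, and "the series" means these compounds.

In a functional assay on CHO-K1 cells with Glucose-dependent insulinotropic receptor (Homo sapiens) as the target, read by a luciferase reporter, with a stated time of 5 h (a lower number here means a smaller maximal response, a higher number a larger maximal response), three compounds have been measured:
Compound 1 `CCSC(=O)N1CCC(Oc2ncnc3c2CCN3c2ccc(S(C)(=O)=O)cc2F)CC1` gives 128%.
Compound 2 `CC(C)c1noc(N2CCC(Oc3ncnc4c3CCN4c3ccc(S(C)(=O)=O)cc3F)CC2)n1` gives 124%.
Compound 3 `CC(C)OC(=O)N1CCC(Oc2ncnc3c2CCN3c2ccc(S(C)(=O)=O)nc2)CC1` gives 97%.

Compound 3 has the lowest of the three numbers; compound 2 is the nearest and compound 1 the furthest, both beyond the scatter. Among the compounds with values here, the one measured step, a number 4 percentage points lower from compound 1 to compound 2 (within the scatter), changes the group on the amine nitrogen in a ring and does not touch the place altered here. Compound 4 `CC(C)OC(=O)N1CCC(Oc2ncnc3c2CCN3c2ccc([S@+](C)[O-])c(F)c2)CC1` differs from compound 3 as follows: a group of 10 heavy atoms (7 carbon, 1 oxygen, 1 fluorine, 1 sulfur; one six-membered aromatic ring of carbon only) in place of a group of 10 heavy atoms (6 carbon, 1 nitrogen, 2 oxygen, 1 sulfur; one six-membered aromatic ring with 1 hetero atom), on a nitrogen on an aromatic ring in a ring. Within the data shown here, no measured step bears on this change; the direction of a step in this assay is open, and a wide range is kept. Compound 4 is estimated at 100%, between 65% and 135%. The expected step is a number 3 percentage points higher from compound 3 to compound 4 (within the scatter).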

Compound 4, largest response reached (reported as percent of maximum), in percent of the reference or control that the assay uses: 122%
Compound 4: the middle estimate sits 22 percentage points below what was measured; the range from low to high includes it.
By their numbers in this assay, from the lowest: compound 3; then compounds 4, 2 and 1 (each within the scatter of the next).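

In this assay the group at this place, on a nitrogen on an aromatic ring, does affect the maximal response: there is a number 25 percentage points higher from compound 3 to compound 4 (beyond the scatter). The change replaces 6-(methylsulfonyl)pyridin-3-yl with a group built on a six-membered aromatic ring of carbon only, so the ring and its sulfur group change together. Nothing available explains the rise.

Which of these parts carries the step remains open. So does the response with a nitrile or a carboxylic acid in place of the sulfur group, or with the opposite arrangement at the stereocentre.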